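The source may report more compounds than this note shows. Statements on the series, on what has been measured and on what is new or still open speak of the compounds shown alone.

Measured compounds in a physicochemical assay for solubility, at pH 2.1; on this read-out higher numbers stand for higher solubility and lower numbers for lower solubility:
- compound 1 `O=C(O)c1ccc(-n2cc(C(=O)c3c(Cl)cccc3Cl)c3cccnc32)cc1`: 1000 nM
- compound 2 `O=C(O)c1ccc(-n2cc(C(=O)c3c(Cl)cccc3Cl)c3cccnc32)c(F)c1`: < 1000 nM

Compound 2 stands only at a limit of this assay, not at a number, namely (the limit of < 1000 nM in this assay, at which 1 of the 2 values shown sits). Among the compounds with values here, the one measured step, a number no higher from compound 1 to compound 2 (the limit leaves the size open), is therefore open in size and concerns a different change, fluoro in place of hydrogen on an aromatic carbon.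

Compound 3 `Cc1cccc(Cl)c1C(=O)c1cn(-c2ccc(C(=O)O)cc2F)c2ncccc12` is not yet measured. It differs from compound 2 by methyl in place of chloro on an aromatic carbon. Within the data shown here, no measured step shows this change on this core, so the expectation rests on where compound 2 already sits. Compound 3 is expected to remain near the limit, with a step that the limit leaves unreadable from compound 2 to compound 3 as the estimated step, not clearly beyond the scatter in either direction. The expected value for compound 3 in this assay is 700 nM, within a range of 200 nM to 2000 nM, with a fair chance that only a limit is again reported.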

Compound 3, solubility: < 1000 nM
Compound 3: a limit, no number (the forecaster's own chance of this, stated with the estimate: 60%); the middle value is on the limit's open side.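

In this assay, compound 2 and compound 3 each give only a limit, not a number, so no step can be read between them: the limit of < 1000 nM in this assay, at which 2 of the 3 values shown sit.

From the compounds shown here alone, both the size and the direction of the change from 2,6-dichlorophenyl to 2-chloro-6-methylphenyl in this assay remain open.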